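The source may hold more compounds than are shown below. What is called first, only, known or untested is meant among the compounds shown, and "the series" means these compounds.

Compound 1 `O=C(Nc1ccc(-n2ccc3nc(C(=O)NCc4ccccc4)ccc32)cc1)Nc1ccc(Cl)c(C(F)(F)F)c1` carries a benzyl group on an amide-type nitrogen at one end of the shared core and a urea at the other. In a functional assay on A375P cells (Homo sapiens) for cytotoxicity, read by MTT assay (a lower number here means a stronger inhibitor, a higher number a weaker inhibitor), compound 1 gives 1100 nM, the upper of the two numbers reported, though its gap to compound 3 lies within the scatter. Compound 3 `O=C(Nc1ccc(-n2ccc3nc(C(=O)NCc4ccccc4)ccc32)cc1)c1ccc(Cl)c(C(F)(F)F)c1` gives 700 nM. That change amounts to a 1.6-fold lower number from compound 1 to compound 3 (0.20 log units; within the scatter). Compound 2 `O=C(Nc1ccc(-n2ccc3nc(C(=O)NCc4ccccc4)ccc32)cc1)Nc1cccc(Cl)c1Cl` reaches only a limit of the assay, > 10000 nM (the limit of > 10000 nM in this assay, at which 1 of the 3 values shown sits). The corresponding steps are an at least 9.0-fold higher number from compound 1 to compound 2 (0.95 log units; beyond the scatter) and an at least 14-fold lower number from compound 2 to compound 3 (1.15 log units; beyond the scatter). Compound 4 `NC(=O)c1ccc2c(ccn2-c2ccc(NC(=O)Nc3ccc(Cl)c(C(F)(F)F)c3)cc2)n1` differs from compound 1 in one place: hydrogen in place of benzyl on an amide-type nitrogen. Going by the values given here, no measured step touches that place; all alter the urea or amide end, so they give no guide. Compound 4 is expected to show a 1.4-fold higher number from compound 1 to compound 4 (0.13 log units; within the scatter), within the scatter. Compound 4 is estimated at 1500 nM, between 400 nM and 6000 nM.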

Compound 4, half-maximal inhibitory concentration: 9900 nM
Compound 4: the middle estimate sits 6.6-fold (0.82 log units) below what was measured, outside the stated range (above it).
By their numbers in this assay, from the lowest: compounds 3 and 1 (each within the scatter of the next); then compound 4. At a limit, above all of these: compound 2.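

Going by these compounds alone, every earlier step altered the urea or amide end, so this is the first reading of the other end of the shared core. In this assay, going from benzylcarbamoyl to carbamoyl brings a 9.0-fold higher number from compound 1 to compound 4 (0.95 log units; beyond the scatter) and so shows that, with the urea held fixed, this position is not indifferent to the change. Nothing measured here explains this loss.

The compounds shown carry only hydrogen or benzyl on this nitrogen, so the outcome with a methyl group or a longer phenethyl chain stays open. On these data alone, whether the same step holds with the amide end of compound 3 also stays open.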